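Fluoro removal on the aryl ether in a pyrimidine amide series

The source may hold more compounds than are shown below. What is called first, only, known or untested is meant among the compounds shown, and "the series" means these compounds.

Compound 1 `CCc1ccc(-c2cc(C(=O)Nc3ccc(Oc4ccnc(C(=O)NC)c4)cc3)ncn2)cc1`, compound 2 `CCc1ccc(-c2cc(C(=O)Nc3ccc(Oc4ccnc(C(=O)NC)c4)c(F)c3)ncn2)cc1` and compound 3 `CNC(=O)c1cc(Oc2ccc(NC(=O)c3cc(-c4ccc(OC)cc4)ncn3)cc2F)ccn1` were measured in a functional assay on MCF7 cells (Homo sapiens) for cytotoxicity, read by MTT assay, with a stated time of 72 h; on this read-out higher numbers stand for weaker inhibition and lower numbers for stronger inhibition. Compound 1 gives 6350 nM, compound 2 gives 7630 nM and compound 3 gives 46200 nM; compound 3 stands furthest from the other two, a 6.1-fold higher number from compound 2 to compound 3 (0.78 log units; beyond the scatter). The cores of compound 2 and compound 3 differ by methoxy in place of ethyl on an aromatic carbon.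

Compound 4 `CNC(=O)c1cc(Oc2ccc(NC(=O)c3cc(-c4ccc(OC)cc4)ncn3)cc2)ccn1` is not yet measured. It differs from compound 3 by hydrogen in place of fluoro on an aromatic carbon. The same change is made from compound 2 to compound 1, where it gave a 1.2-fold lower number from compound 2 to compound 1 (0.08 log units; within the scatter). The place is the same in both pairs, so the change is the same.

For compound 4 in this assay the step is expected to be small, a 1.2-fold lower number from compound 3 to compound 4 (0.06 log units; within the scatter), because the matched step a 1.2-fold lower number from compound 2 to compound 1 (0.08 log units; within the scatter) lies within the scatter. On that single precedent compound 4 is estimated at 40000 nM, with a range from 20000 nM to 80000 nM.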

Compound 4, half-maximal inhibitory concentration: 29200 nM
Beside the measured number, compound 4's estimate is 1.4-fold (0.14 log units) above it; the measured number falls inside the stated range.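

In this assay, hydrogen in place of the fluoro ortho to the (2-(methylcarbamoyl)pyridin-4-yl)oxy group gives a 1.6-fold lower number from compound 3 to compound 4 (0.20 log units; within the scatter), and this step agrees with the one seen on the core of compound 1: the same change on two cores in this assay, a 1.2-fold lower number (0.08 log units; within the scatter) from compound 2 to compound 1 and a 1.6-fold lower number (0.20 log units; within the scatter) from compound 3 to compound 4, 1.3-fold (0.12 log units) apart, within the scatter of two such steps. Methoxy in place of ethyl, now read on the core without the fluoro, gives a 4.6-fold higher number from compound 1 to compound 4 (0.66 log units; beyond the scatter), and it too agrees with its earlier counterpart: the same change on two cores in this assay, a 6.1-fold higher number (0.78 log units; beyond the scatter) from compound 2 to compound 3 and a 4.6-fold higher number (0.66 log units; beyond the scatter) from compound 1 to compound 4, 1.3-fold (0.12 log units) apart, within the scatter of two such steps. Each change therefore carries between the two cores among these four compounds, but with only two pairs per change in a single cell assay, this does not show that either step holds on other cores, nor does it explain the size of either step.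

From the compounds shown here alone, it remains open whether a chloro or a methyl at the fluoro's place would also leave the number within the scatter. Going by these compounds, it is equally open how a propyl, an ethoxy or a dimethylamino group would compare with the ethyl and methoxy groups.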